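Methyl on the anilide: compound 2 to compound 3

This account rests on a few compounds, and the source may have more. Where it says the series, first, only, none or still open, it means among the compounds named here.

Compound 1 `CC1=C(C(=O)Nc2ccc(C)cc2)C(c2cn(-c3ccccc3)nc2-c2ccccc2)NC(=O)N1`: 71700 nM
Compound 2 `CC1=C(C(=O)Nc2ccccc2)C(c2cn(-c3ccccc3)nc2-c2ccc(Cl)cc2)NC(=O)N1`: 65500 nM

Of the compounds shown here, two have been measured in a functional assay on MCF7 cells (Homo sapiens) for inhibition, read by sulforhodamine B assay, with a stated time of 24 h; on this read-out lower numbers stand for stronger inhibition of growth and higher numbers for weaker inhibition of growth. Compound 2 gives the lowest of the two numbers in this assay, but its nearest neighbour, compound 1, lies within the scatter, so the two cannot be ranked. Compound 3 `CC1=C(C(=O)Nc2ccc(C)cc2)C(c2cn(-c3ccccc3)nc2-c2ccc(Cl)cc2)NC(=O)N1` is not yet measured. It differs from compound 2 by methyl in place of hydrogen on an aromatic carbon. Compound 1 already carries this methyl and sits close to compound 2, so no step beyond the scatter is expected. Compound 3 is estimated at 62000 nM, range 28000 nM to 140000 nM, a step of a 1.1-fold lower number from compound 2 to compound 3 (0.02 log units; within the scatter).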

Compound 3, concentration for 50% growth inhibition: 69700 nM
Beside the measured number, compound 3's estimate is 1.1-fold (0.05 log units) below it; measured number inside the range.
By their numbers in this assay, from the lowest: compounds 2, 3 and 1 (each within the scatter of the next).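

In this assay, the change from phenyl to 4-methylphenyl gives a 1.1-fold higher number from compound 2 to compound 3 (0.03 log units; within the scatter) and stays within the scatter, so this methyl makes no readable difference when the chloro group is present. The added chloro group gives a 1.0-fold lower number from compound 1 to compound 3 (0.01 log units; within the scatter) and also stays within the scatter, so with the methyl present that change cannot be read either. No measurement here explains these results.
Going by these compounds, whether an amine, a methoxy group or a carboxylic acid at the methyl's place would give a number clearly apart from these remains open.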